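From Cyclobutyl to Benzyloxy: An Expected Step

This account rests on a few compounds, and the source may have more. Where it says the series, first, only, none or still open, it means among the compounds named here.

Of the compounds shown here, two have been measured in a functional assay for inhibition of sodium/hydrogen exchanger (Oryctolagus cuniculus); on this read-out higher numbers stand for weaker inhibition and lower numbers for stronger inhibition. Compound 1 `CCc1cc(Cl)c(S(C)(=O)=O)cc1C(=O)N=C(N)N` gives 63 nM in this assay. Compound 2 `Cc1cc(C2CCC2)c(S(C)(=O)=O)cc1C(=O)N=C(N)N` gives 8.2 nM in this assay, the lower of the two numbers and thus the stronger inhibitor of the pair; its gap from compound 1 lies beyond the usual scatter of repeated measurements. Compound 3 `Cc1cc(OCc2ccccc2)c(S(C)(=O)=O)cc1C(=O)N=C(N)N` has not yet been measured. It differs from compound 2 in one place: benzyloxy in place of cyclobutyl on an aromatic carbon. The cyclobutyl leaves and the benzyloxy enters on an aromatic carbon ortho to a methylsulfonyl group. Among the measured compounds shown here, no measured pair shows a like exchange, so the expected step rests only on the two numbers at hand. In this assay the exchange is expected to give a 2.4-fold higher number from compound 2 to compound 3 (0.39 log units; beyond the scatter), a moderate move toward weaker inhibition that may still fall within the scatter. Compound 3 is estimated at 20 nM, with a range from 5 nM to 80 nM.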

Compound 3, half-maximal inhibitory concentration: 28 nM
Compound 3: middle estimate off by 1.4-fold (0.15 log units), on the low side, and the stated range covers the measured number.
By their numbers in this assay, from the lowest: compound 2; then compound 3; then compound 1.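

In this assay the exchange of cyclobutyl for benzyloxy on the aromatic carbon ortho to a methylsulfonyl group gives a 3.4-fold higher number from compound 2 to compound 3 (0.53 log units; beyond the scatter) and so provides a direct measure of a change at this position. The position accepts benzyloxy, with its 8 heavy atoms, a six-membered aromatic ring and a hydrogen-bond acceptor, in place of cyclobutyl, with its 4 heavy atoms, and compound 3 gives 28 nM with a modest move toward weaker inhibition. Nothing measured here accounts for the size or direction of this step. Going by these compounds, the oxygen and the aromatic ring of benzyloxy enter together, so their separate contributions remain open, and methoxy or phenyl on the same carbon would divide them. On these data alone, how an amine or a carboxylic acid at this position would read also remains open.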